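The source may report more compounds than this note shows. Statements on the series, on what has been measured and on what is new or still open speak of the compounds shown alone.

Three compounds of the shared core have numbers. Compound 1 `CC(C)C[C@H](N)CN(C(=O)[C@@H]1C[C@H]1c1ccccc1)c1ccc(-c2ccncc2)cc1` gives 13000 nM in a functional assay for agonist activity at G protein-coupled receptor 88 (Homo sapiens), read by HTRF and cAMP accumulation; a higher number here means that more compound is needed for the effect, a lower number that less compound is needed. Compound 2 `Cc1ccc(-c2ccc(N(C[C@@H](N)CC(C)C)C(=O)[C@@H]3C[C@H]3c3ccccc3)cc2)cc1` gives 360 nM in this assay, and compound 3 `COc1cccc(-c2ccc(N(C[C@@H](N)CC(C)C)C(=O)[C@@H]3C[C@H]3c3ccccc3)cc2)c1` gives 1100 nM in this assay. Compound 3 therefore stands second of the three: it needs less compound than compound 1, as the step of a 12-fold lower number from compound 1 to compound 3 (1.07 log units; beyond the scatter) shows, and more than compound 2, as the step of a 3.1-fold higher number from compound 2 to compound 3 (0.49 log units; beyond the scatter) shows. The step of a 36-fold lower number from compound 1 to compound 2 (1.56 log units; beyond the scatter) is the largest seen so far.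

Compound 4 `CC(C)C[C@H](N)CN(C(=O)[C@@H]1C[C@H]1c1ccccc1)c1ccc(-c2ccc(F)cc2)cc1` has not been measured. The change from compound 3 is 4-fluorophenyl in place of 3-methoxyphenyl on an aromatic carbon. Within the data shown here, the steps that bear on it are the two replacements of pyridin-4-yl by a carbon-only ring, both large, and the modest step from 4-methylphenyl to 3-methoxyphenyl. Compound 4 is expected to stay well within the range set by compound 2 and compound 3; the expected step of a 2.0-fold lower number from compound 3 to compound 4 (0.30 log units; within the scatter) is toward a lower number, modest in size. The estimated value for compound 4 in this assay is 550 nM, with a range from 200 nM to 1500 nM.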

Compound 4, half-maximal effective concentration: 900 nM
Beside the measured number, compound 4's estimate is 1.6-fold (0.21 log units) below it; low and high end bracket the measured number.
By their numbers in this assay, from the lowest: compound 2; then compounds 4 and 3 (each within the scatter of the next); then compound 1.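

In this assay, the step of a 1.2-fold lower number from compound 3 to compound 4 (0.09 log units; within the scatter) shows that, at this place, 4-fluorophenyl and 3-methoxyphenyl give values within the scatter of each other, even though the two rings differ in what they carry and in hydrogen-bond acceptor count. The step of a 2.5-fold higher number from compound 2 to compound 4 (0.40 log units; beyond the scatter) shows that fluoro and methyl on the same ring can still be told apart, while the step of a 14-fold lower number from compound 1 to compound 4 (1.16 log units; beyond the scatter) adds a third carbon-only ring that stands well clear of pyridin-4-yl. Nothing available gives a reason for any of these differences.

Still open, on these data alone, is how a plain phenyl or a 4-chlorophenyl would compare with 4-methylphenyl at this place. Also open, as far as these compounds go, is how the series would respond to a ring carrying an amine or a carboxylic acid.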